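Series notes: amino-ester side chains on a shared core

A few compounds are considered here, and "the series" means these few. Any claim that something is new, unique, unknown or untested is made for them only; others in the source may bear on it.

Measured so far in a functional assay on BGC-823 cells (Homo sapiens) for cytotoxicity, read by MTT assay, with a stated time of 24 h; a higher number here means a weaker inhibitor, a lower number a stronger inhibitor:
- compound 1, `COC(=O)[C@H](NC(=O)Cn1cc(C2=C(c3c[nH]c4ccccc34)C(=O)N(C)C2=O)c2ccccc21)[C@@H](C)O`, gives 23300 nM
- compound 2, `COC(=O)[C@@H](CO)NC(=O)Cn1cc(C2=C(c3c[nH]c4ccccc34)C(=O)N(C)C2=O)c2ccccc21`, gives 28900 nM

Compound 2 holds the highest of the two numbers shown in this assay, with compound 1 nearest; the single measured step, a 1.2-fold higher number from compound 1 to compound 2 (0.09 log units; within the scatter), lies within the scatter, so the two values cannot be ordered.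

The next compound, compound 3, `COC(=O)[C@@H](CC(C)C)NC(=O)Cn1cc(C2=C(c3c[nH]c4ccccc34)C(=O)N(C)C2=O)c2ccccc21`, is not yet measured. It differs from compound 2 by isopropyl in place of hydroxy on a saturated chain carbon, two bonds along the chain from an amide-type nitrogen and a carbonyl carbon. Within the data shown here, no measured step bears directly on this change: the only step in hand exchanges a methyl for hydrogen on the side chain and stays within the scatter, which says nothing about removing the hydroxy in favour of an isopropyl. With both measured values close together and no step beyond the scatter anywhere in the series, the expectation for compound 3 rests on that flat picture alone.

Compound 3 is therefore expected to land near compound 2, a step of a 1.3-fold lower number from compound 2 to compound 3 (0.12 log units; within the scatter), that is, no change beyond the scatter is expected. The estimate for compound 3 in this assay is 22000 nM, with a range from 7000 nM to 70000 nM.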

Compound 3, half-maximal inhibitory concentration: 45500 nM
Estimate against measurement, compound 3: 2.1-fold (0.32 log units) below; the range from low to high includes it.
By their numbers in this assay, from the lowest: compounds 1, 2 and 3 (each within the scatter of the next).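

Isopropyl in place of hydroxy on a saturated chain carbon, two bonds along the chain from an amide-type nitrogen and a carbonyl carbon, gives a 1.6-fold higher number from compound 2 to compound 3 (0.20 log units; within the scatter) in this assay, so this position now has a first reading for an exchange that removes the hydroxy altogether, and that reading stays inside the scatter. The broader exchange of isobutyl in place of 1-hydroxyethyl gives a 2.0-fold higher number from compound 1 to compound 3 (0.29 log units; within the scatter), which is also printed as within the scatter, so the values do not separate the two hydroxy-bearing side chains from the one without a hydroxy, and no order can be set among the three compounds. No supporting data accompany these values that could account for them.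

The compounds shown leave open whether an amine on this side chain, or a chain longer than isobutyl, would give a step beyond the scatter in this assay. All three compounds also share the methyl ester and the core, so the outcome of a carboxylic acid in place of that ester remains an open question for the series.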